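A Dichlorophenyl Swap on the Shared Core

A few compounds are considered here, and "the series" means these few. Any claim that something is new, unique, unknown or untested is made for them only; others in the source may bear on it.

Measured so far:
- compound 1 `Cc1oc2c([C@H]3CCN(C)C[C@H]3O)c(O)cc(O)c2c(=O)c1C(O)c1ccccc1Br`: 10%
- compound 2 `Cc1oc2c([C@H]3CCN(C)C[C@H]3O)c(O)cc(O)c2c(=O)c1C(O)c1c(F)cccc1Cl`: 41%

In a functional assay on MIA PaCa-2 cells (Homo sapiens) for inhibition, read by MTT assay, with a stated time of 48 h, tested at 10 uM (a lower number here means less inhibition of growth, a higher number more inhibition of growth at the concentration tested), compound 2 stands highest of the two at 41%. Compound 3 `Cc1oc2c([C@H]3CCN(C)C[C@H]3O)c(O)cc(O)c2c(=O)c1C(O)c1cccc(Cl)c1Cl` has not yet been measured and differs from compound 2 in a single group: 2,3-dichlorophenyl in place of 2-chloro-6-fluorophenyl on a saturated chain carbon bound to an aromatic carbon and an oxygen on a saturated carbon. In words, 2,3-dichlorophenyl takes the place of 2-chloro-6-fluorophenyl on a saturated chain carbon bound to an aromatic carbon and an oxygen on a saturated carbon. Among the compounds with values here, only one measured step bears on this change, at the same place: a number 31 percentage points higher from compound 1 to compound 2 (beyond the scatter). That large step shows that swapping this group can move the result well beyond the scatter. Compound 3, like compound 1, carries no fluorine, and compound 1 gave 10%, so a moderate fall is expected, though this rests on thin evidence. The expected change is a number 11 percentage points lower from compound 2 to compound 3 (beyond the scatter). For compound 3 the estimate is 30%, with an expected range of 12% to 50%.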

Compound 3, percent growth inhibition at one concentration: 2%
The estimate for compound 3 lay 28 percentage points above the measured number; the measured number lies below the stated range.
By their numbers in this assay, from the lowest: compounds 3 and 1 (each within the scatter of the next); then compound 2.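

Changing only the halogens on this phenyl ring can decide the outcome in this assay, where there is a number 39 percentage points lower from compound 2 to compound 3 (beyond the scatter) even though the entering and leaving groups have the same count of heavy atoms. Two groups without fluorine, 2-bromophenyl and 2,3-dichlorophenyl, now read alike, with a number 8 percentage points lower from compound 1 to compound 3 (within the scatter) and no real separation between them. Among these three compounds, the higher number therefore stays with 2-chloro-6-fluorophenyl alone, and no measurement available here explains why this group stands apart.

On these data alone, whether the fluorine itself matters remains open, as does whether a plain 2-fluorophenyl or a phenyl ring carrying a methoxy group or an amine would match compound 2. With a single tested concentration, how these compounds would compare across a range of doses is also unknown.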